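The source may report more compounds than this note shows. Statements on the series, on what has been measured and on what is new or still open speak of the compounds shown alone.

Compound 1 `O=C(Nc1ccc(Cl)cc1CN1C(=O)c2ccccc2C1=O)c1ccccc1[N+](=O)[O-]`: in an assay on CHO cells for positive allosteric modulation of metabotropic glutamate receptor 5 (Homo sapiens), read by FLIPR (on this read-out lower numbers stand for an effect already at smaller amounts and higher numbers for an effect only at larger amounts of compound), compound 1 gives 5700 nM. Compound 2 `O=C(Nc1ccc(Cl)cc1CN1C(=O)c2ccccc2C1=O)c1ccccc1`: in this assay compound 2 reaches only the assay limit of > 100000 nM.

Compound 2 thus stands at the edge of what this assay can report; only a limit is known for it. For the measured compounds named here, the one measured step, an at least 17-fold higher number from compound 1 to compound 2 (1.24 log units; beyond the scatter), concerns hydrogen in place of nitro on an aromatic carbon. Compound 3 `O=C(Nc1ccc(Cl)cc1CN1C(=O)c2ccccc2C1=O)c1ccco1` differs from compound 2 by furan-2-yl in place of phenyl on a carbonyl carbon. Going by the values given here, that measured step touches a different part of the molecule and does not bear on this change, so no measured step sets the size or direction expected in this assay. Compound 3 is estimated at 100000 nM, between 20000 nM and 500000 nM. The expected step is a number no higher from compound 2 to compound 3 (the limit leaves the size open).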

Compound 3, half-maximal effective concentration: 2300 nM
Estimate against measurement, compound 3: 43-fold (1.64 log units) above; the measured number lies below the stated range.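

In this assay, a change of ring on the carbonyl carbon alone brings back a measurable effect without any nitro group: an at least 43-fold lower number from compound 2 to compound 3 (1.63 log units; beyond the scatter). Compound 2 is known only by a limit of the assay: the limit of > 100000 nM in this assay, at which 1 of the 3 values shown sits. Furan-2-yl also outperforms 2-nitrophenyl at this position, with a 2.5-fold lower number from compound 1 to compound 3 (0.39 log units; beyond the scatter), so a nitro group is not required here for an effect.

The compounds shown do not separate the part played by the ring oxygen of furan-2-yl from that of the five-membered ring. Going by these compounds, how thiophen-2-yl or pyridin-2-yl would read on this carbonyl carbon in this assay also stays open.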